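The compounds below may be only part of what the source reports. "The series", "measured", "known", "first", "only" and "open" are said of these compounds alone.

Measured compounds:
compound 1 `CC(c1ccc(-c2ccccc2)c(F)c1)c1nnc2n1N=C(c1ccc(OC(F)(F)F)cc1)CS2` with 8400 nM
compound 2 `CC(c1ccc(-c2ccccc2)c(F)c1)c1n[nH]c(=S)n1N` with 43100 nM
compound 3 `COc1ccc2cc(C(C)c3nnc4n3N=C(c3ccc(Cl)cc3)CS4)ccc2c1` with 5600 nM

In a functional assay on Huh-7 cells (Homo sapiens) for inhibition, read by sulforhodamine B assay, with a stated time of 72 h (a lower number here means a stronger inhibitor, a higher number a weaker inhibitor), compound 1 gives 8400 nM, the second highest of the three numbers. Its nearest neighbour is compound 3, which in this assay gives 5600 nM, a gap that stays within the scatter of repeated measurements, so the two cannot be ranked against each other. Its furthest neighbour is compound 2, which in this assay gives 43100 nM, a gap beyond the scatter; compound 2 lacks the fused bicyclic core that compounds 1 and 3 share, and this is the only clear separation among the three.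

The unmeasured compound 4 `CC(c1ccc(-c2ccccc2)c(F)c1)c1nnc2n1N=C(c1ccc(F)cc1)CS2` keeps the core and the fluorinated biphenyl of compound 1 and changes only the pendant aryl: fluoro in place of trifluoromethoxy on an aromatic carbon. Going by the values given here, no pair of measured compounds shows this exact change, so its size cannot be read from the data. Compounds 1 and 3 carry different pendant aryl groups and differ only within the scatter, which suggests that this position tolerates variation. On that basis compound 4 is expected to give 10000 nM in this assay, in a range from 4000 nM to 25000 nM, meaning a step from compound 1 to compound 4 of a 1.2-fold higher number from compound 1 to compound 4 (0.08 log units; within the scatter), which is estimated to be none beyond the scatter.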

Compound 4, half-maximal inhibitory concentration: 4900 nM
Compound 4: the middle estimate sits 2.0-fold (0.31 log units) above what was measured; the range from low to high includes it.
By their numbers in this assay, from the lowest: compounds 4, 3 and 1 (each within the scatter of the next); then compound 2.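

In this assay, going by these compounds alone, replacing trifluoromethoxy with fluoro on this aromatic carbon gives a 1.7-fold lower number from compound 1 to compound 4 (0.23 log units; within the scatter), the first reading of a change at this position with the shared core and the fluorinated biphenyl held constant. Within the data shown here, the earlier comparison of compound 1 with compound 3 could only hint at tolerance here, since those two compounds differ in more than one place, whereas this pair isolates the single change. It shows that a group of 5 heavy atoms with 1 hydrogen-bond acceptor can give way to a single fluorine, with no hydrogen-bond acceptor counted, without the number moving beyond the scatter, and no available evidence speaks to why the two compounds read alike.

The compounds shown cover only halogen-bearing substituents at this position, so it remains open whether an amine, a carboxylic acid or a longer alkyl chain in the same place would also stay within the scatter. They also leave open whether this change would read the same with the group that compound 3 carries in place of the fluorinated biphenyl.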